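Aryl exchange on the saturated ring carbon: compound 4

The compounds below may be only part of what the source reports. "The series", "measured", "known", "first", "only" and "open" are said of these compounds alone.

Three compounds share one core: compound 1 `Cc1cc(C)cc(NC(=O)CN2CCC(c3cccc[n+]3[O-])CC2)c1`, compound 3 `O=C(CN1CCC(c2cccc[n+]2[O-])CC1)Nc1ccc(F)cc1` and compound 2 `Cc1cccc(NC(=O)CN2CCC(c3cccc(O)c3)CC2)c1`. In a functional assay on HEK293 cells for agonist activity at D(4) dopamine receptor (Homo sapiens), read by FLIPR (a lower number here means a smaller maximal response, a higher number a larger maximal response), compound 1 gives 76%, compound 3 gives 71% and compound 2 gives 66%. On paper the number of compound 2 is the smallest of the three, yet its gaps to compound 3 and to compound 1 both lie within the scatter, so the three stand level. Among the compounds with values here, the only single-site step measured, a number 5 percentage points lower from compound 1 to compound 3 (within the scatter), concerns the group on the amide-type nitrogen and is within the scatter; it does not touch the position changed here. Compound 4 `Cc1cccc(NC(=O)CN2CCC(c3ccccc3C)CC2)c1` differs from compound 2 by 2-methylphenyl in place of 3-hydroxyphenyl on a saturated ring carbon. Within the data shown here, no measured step bears directly on this exchange; what compounds 1 and 3 show is that another group at this carbon still falls within the scatter of compound 2. The step is therefore expected to stay within the scatter: a number 2 percentage points higher from compound 2 to compound 4 (within the scatter). Compound 4 is estimated at 68%, with a range from 52% to 84%.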

Compound 4, largest response reached (reported as efficacy), in percent of the reference or control that the assay uses: 43%
For compound 4 the middle estimate is 25 percentage points above the measured one, outside the stated range (below it).
By their numbers in this assay, from the lowest: compound 4; then compounds 2, 3 and 1 (each within the scatter of the next).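

In this assay, within the data shown here, the exchange gives a number 23 percentage points lower from compound 2 to compound 4 (beyond the scatter), the only step so far that lies beyond the scatter, so the maximal response does depend on which aryl group this saturated ring carbon carries. The exchange keeps the heavy-atom count at 7 and the six-membered aromatic ring, while the hydrogen-bond donor and acceptor counts go from 1 to 0. Nothing available explains the step.

The single step changes both the substituent and its ring position, and the compounds shown do not separate the two. Going by these compounds, how a plain phenyl or an aminophenyl group at this carbon would compare with compound 2 and compound 4 remains open.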